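The compounds below may be only part of what the source reports. "The series", "measured", "known", "first", "only" and "open" are said of these compounds alone.

Measured so far in a functional assay on MCF7 cells (Homo sapiens) for antiproliferative activity; on this read-out higher numbers stand for weaker inhibition and lower numbers for stronger inhibition:
- compound 1 `CC(C)=CCc1cc(C(=O)Nc2cc3ccc(OCCC4CCCCN4)c(C)c3oc2=O)ccc1O`: 710 nM
- compound 2 `CC(C)=CCc1cc(C(=O)Nc2cc3ccc(OCC4CCCN(C)C4)c(C)c3oc2=O)ccc1O`: 2640 nM
- compound 3 `CC(C)=CCc1cc(C(=O)Nc2cc3ccc(OCCCNCCO)c(C)c3oc2=O)ccc1O`: 1560 nM

Compound 3 stands with compound 2 at the weaker end of this small set. The gap between them stays within the usual scatter: a 1.7-fold lower number from compound 2 to compound 3 (0.23 log units; within the scatter). Compound 1 gives the lowest number of the three, and the step to compound 3 is modest: a 2.2-fold higher number from compound 1 to compound 3 (0.34 log units; beyond the scatter).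

The next compound, compound 4 `CC(C)=CCc1cc(C(=O)Nc2cc3ccc(OCCCNCc4ccccc4)c(C)c3oc2=O)ccc1O`, puts phenyl in place of hydroxymethyl on a saturated chain carbon bound to an amine nitrogen. Within the data shown here, no measured pair makes this exact swap. The nearest evidence comes from the two steps above, which also change the amine-bearing side chain, and neither is large. The third step, a 3.7-fold higher number from compound 1 to compound 2 (0.57 log units; beyond the scatter), is also modest. These steps give no direction for the new change, so no shift beyond the scatter is expected in this assay.

The expected change is a 1.2-fold lower number from compound 3 to compound 4 (0.08 log units; within the scatter). For compound 4 the estimated value is 1300 nM, with an expected range from 500 nM to 3400 nM.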

Compound 4, half-maximal inhibitory concentration: 910 nM
Beside the measured number, compound 4's estimate is 1.4-fold (0.15 log units) above it; low and high end bracket the measured number.
By their numbers in this assay, from the lowest: compounds 1, 4, 3 and 2 (each within the scatter of the next, the first and the last beyond it).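

In this assay, this place on the chain accepts phenyl for hydroxymethyl, a group of more heavy atoms with an aromatic ring and no hydrogen-bond donor, without a shift beyond the scatter: a 1.7-fold lower number from compound 3 to compound 4 (0.23 log units; within the scatter). The benzylamino chain also separates from the 1-methylpiperidin-3-yl side chain, a 2.9-fold lower number from compound 2 to compound 4 (0.46 log units; beyond the scatter), while staying within the scatter of the piperidin-2-yl side chain, a 1.3-fold higher number from compound 1 to compound 4 (0.11 log units; within the scatter), and the 2-hydroxyethyl chain showed neither of these two results. The data available give no explanation for this pattern.

The compounds shown leave open whether a benzyl ring carrying a substituent, such as fluorine or methoxy, would give a lower number. They also leave open how a longer link, such as 2-phenylethyl on the amine, or a carboxylic acid at this place would read out.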